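Cytotoxicity limits across the aryl-isoxazole series

A few compounds are considered here, and "the series" means these few. Any claim that something is new, unique, unknown or untested is made for them only; others in the source may bear on it.

Compound 1 `COc1ccc(-c2cc(COC(Cc3cn(C4CCN(Cc5ccc([N+](=O)[O-])cc5)CC4)nn3)c3ccc(Br)cc3)on2)cc1`: in an ADME assay on cells (Fibroblast, Homo sapiens) for cytotoxicity, with a stated time of 48 h (on this read-out lower numbers stand for stronger inhibition and higher numbers for weaker inhibition), compound 1 gives > 25000 nM, a limit of the assay.
Compound 2 `N#Cc1cccc(-c2cc(COC(Cc3cn(C4CCN(Cc5ccc([N+](=O)[O-])cc5)CC4)nn3)c3ccc(Br)cc3)on2)c1`: in this assay compound 2 gives > 25000 nM, a limit of the assay.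
Compound 3 `O=[N+]([O-])c1ccc(CN2CCC(n3cc(CC(OCc4cc(-c5ccccc5Br)no4)c4ccc(Br)cc4)nn3)CC2)cc1`: in this assay compound 3 gives > 25000 nM, a limit of the assay.

Compound 3 thus stands at the limit, together with the two other measured compounds (the limit of > 25000 nM in this assay, at which 3 of the 3 values shown sit). Compound 4 `COc1ccccc1-c1cc(COC(Cc2cn(C3CCN(Cc4ccc([N+](=O)[O-])cc4)CC3)nn2)c2ccc(Br)cc2)on1` differs from it by methoxy in place of bromo on an aromatic carbon. Among the measured compounds shown here, no measured step bears directly on this change: a step that the two limits leave unreadable from compound 1 to compound 3 and a step that the two limits leave unreadable from compound 2 to compound 3 both end at compound 3 and are unreadable, as is a step that the two limits leave unreadable from compound 1 to compound 2. In this assay compound 4 is therefore expected to sit at the limit as well, with an expected step that the limit leaves unreadable from compound 3 to compound 4 of no readable size. The estimate for compound 4 is 35000 nM, between 15000 nM and 90000 nM.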

Compound 4, half-maximal inhibitory concentration: > 25000 nM
Compound 4 gave a limit, no number; the forecaster's own chance of this, stated with the estimate: 85%; the middle value is on the limit's open side.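

All four compounds sit at the same limit in this assay, so the steps joining compound 4 to compound 1, compound 2 and compound 3 cannot be read: the limit of > 25000 nM in this assay, at which 4 of the 4 values shown sit.

The compounds shown leave open where the true values lie and whether any of these aryl changes alters them.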